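Swapping a ring tail in a CXCR4 agonist series

This account rests on a few compounds, and the source may have more. Where it says the series, first, only, none or still open, it means among the compounds named here.

Compound 1: `c1ccc2c(c1)CN[C@@H](CN(CCCCN(Cc1ccncc1)Cc1ccncc1)[C@H]1CCCc3cccnc31)C2` — > 30000 nM
Compound 2: `c1ccc2c(c1)CN[C@@H](CN(CCCCNCC1CCOCC1)[C@H]1CCCc3cccnc31)C2` — > 30000 nM

In a functional assay on cells for agonist activity at C-X-C chemokine receptor type 4 (Homo sapiens), read by fluorescence and calcium flux, with a stated time of 90 s (a higher number here means that more compound is needed for the effect, a lower number that less compound is needed), compound 1 gives > 30000 nM, which is a limit of the assay rather than a number. In this assay compound 2 likewise gives > 30000 nM, again a limit and not a measured number. Among the measured compounds shown here, both values shown therefore sit at the same limit, as summed up in the limit of > 30000 nM in this assay, at which 2 of the 2 values shown sit, so compound 2 has no measured activity to stand above or below, and no step between the two can be sized.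

Compound 3 is `c1ccc2c(c1)CN[C@@H](CN(CCCCNC1CCNCC1)[C@H]1CCCc3cccnc31)C2`. It differs from compound 2 by piperidin-4-yl in place of (oxan-4-yl)methyl on an amine nitrogen, the difference being piperidin-4-yl in place of (oxan-4-yl)methyl on an amine nitrogen. With nothing measured beyond the limit for compound 2, the step for compound 3 cannot be anchored: a move from compound 2 to compound 3 of an at least 1.5-fold lower number from compound 2 to compound 3 (0.17 log units; that floor lies within the scatter) is expected, which is no more than a guess that the new ring may begin to give a readable number. For compound 3 the estimate in this assay is 20000 nM, with a range from 3000 nM to 30000 nM, and it remains likely that only a limit is reported.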

Compound 3, half-maximal effective concentration: > 30000 nM
Compound 3: no number, only a limit; the forecaster's own chance of this, stated with the estimate: 65%; middle value at least 1.5-fold (0.17 log units) from the limit.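

Compound 3 gives > 30000 nM in this assay, which is a limit of the assay and not a number. Compound 2 also stands at a limit, so the change from compound 2 to compound 3 cannot be read as a step. The compounds shown leave open whether any ring tail on this amine nitrogen gives a readable number, as all the values share one limit: the limit of > 30000 nM in this assay, at which 3 of the 3 values shown sit.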